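Series notes: losing the bromines from compound 2

The source may hold more compounds than are shown below. What is called first, only, known or untested is meant among the compounds shown, and "the series" means these compounds.

Among the measured compounds shown here, in a functional assay on PC-3 cells (Homo sapiens) for cytotoxicity, read by MTT assay, with a stated time of 72 h (on this read-out higher numbers stand for weaker inhibition and lower numbers for stronger inhibition), two compounds have numbers so far. Compound 1 (`O=C(N/N=C/c1ccc(O)cc1)Nc1cc2c(Nc3ccc(F)c(Cl)c3)ncnc2cc1O[C@H]1CCOC1`) gives 4890 nM, and compound 2 (`COc1cc2ncnc(Nc3ccc(F)c(Cl)c3)c2cc1NC(=O)N/N=C/c1cc(Br)c(O)c(Br)c1`) gives 41500 nM. Compound 2 therefore holds the higher of the two numbers, meaning the weaker inhibition, and the gap between them lies beyond the usual scatter. For the measured compounds named here, no measured pair isolates a single structural change.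

Compound 3 (`COc1cc2ncnc(Nc3ccc(F)c(Cl)c3)c2cc1NC(=O)N/N=C/c1ccc(O)cc1`) is the next to be read in this assay. The change from compound 2 is 4-hydroxyphenyl in place of 3,5-dibromo-4-hydroxyphenyl on a carbon with a double bond to nitrogen. Going by the values given here, the entering 4-hydroxyphenyl also occurs in compound 1 at 4890 nM, so a number nearer to that value than to the one for compound 2 is expected, though this rests on a single comparison. The expected step is a 5.2-fold lower number from compound 2 to compound 3 (0.71 log units; beyond the scatter), towards a lower number and stronger inhibition, beyond the scatter. The estimate for compound 3 is 8000 nM, with an expected range of 2500 nM to 25000 nM.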

Compound 3, half-maximal inhibitory concentration: 16600 nM
Beside the measured number, compound 3's estimate is 2.1-fold (0.32 log units) below it, and the stated range covers the measured number.
By their numbers in this assay, from the lowest: compound 1; then compound 3; then compound 2.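

Among the compounds shown here, with 4-hydroxyphenyl in place of 3,5-dibromo-4-hydroxyphenyl on a carbon with a double bond to nitrogen, this assay gives a 2.5-fold lower number from compound 2 to compound 3 (0.40 log units; beyond the scatter) and provides the first reading of a single change at this position: the two bromines are not required for a measurable number, and the step without them runs modestly towards stronger inhibition. For the compounds shown here, compound 3 also gives the first reading at the oxygen on an aromatic ring, where methyl in place of oxolan-3-yl gives a 3.4-fold higher number from compound 1 to compound 3 (0.53 log units; beyond the scatter) with 4-hydroxyphenyl held constant, so oxolan-3-yl goes with the stronger inhibition in this pair. No measurement on hand accounts for either step.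

From the compounds shown here alone, both steps run through compound 3, so whether the effect of the bromines stays the same with oxolan-3-yl on the oxygen remains open, and a single bromine, as in 3-bromo-4-hydroxyphenyl, would show whether the step is divided between the two atoms. At the oxygen on an aromatic ring, a longer chain such as 2-methoxyethyl or a chain ending in an amine remains unplaced relative to methyl and oxolan-3-yl.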